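Substituents on the ring amide nitrogen of a fused core

The source may report more compounds than this note shows. Statements on the series, on what has been measured and on what is new or still open speak of the compounds shown alone.

Measured compounds:
compound 1 `CN(CCC1CCNCC1)C(=O)c1ccc2c(c1)CC(CC(=O)O)C(=O)N(C)C2` gives 33 nM in a functional assay (plasma) for inhibition, with Homo sapiens as the target; on this read-out higher numbers stand for weaker inhibition and lower numbers for stronger inhibition;
compound 2 `CN(CCC1CCNCC1)C(=O)c1ccc2c(c1)CC(CC(=O)O)C(=O)N(CCC(C)(C)C)C2` gives 27 nM in this assay;
compound 3 `CN(CCC1CCNCC1)C(=O)c1ccc2c(c1)CC(CC(=O)O)C(=O)NC2` gives 71 nM in this assay.

Compound 3 has the highest number of the three, with compound 1 nearest and compound 2 furthest. Compound 4 `CN(CCC1CCNCC1)C(=O)c1ccc2c(c1)CC(CC(=O)O)C(=O)N(CCC1CCCCC1)C2` is not yet measured; it differs from compound 3 by 2-cyclohexylethyl in place of hydrogen on an amide-type nitrogen in a ring. For the measured compounds named here, the steps that bear on this are a 2.2-fold higher number from compound 1 to compound 3 (0.33 log units; beyond the scatter) and a 2.6-fold higher number from compound 2 to compound 3 (0.42 log units; beyond the scatter), both modest moves to higher numbers when the ring amide nitrogen loses its substituent. Placing a substituent back on that nitrogen is therefore expected to lower the number by a modest step, a 2.5-fold lower number from compound 3 to compound 4 (0.40 log units; beyond the scatter). Compound 4 is estimated at 28 nM, within 14 nM to 60 nM.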

Compound 4, half-maximal inhibitory concentration: 27 nM
The estimate for compound 4 lay 1.0-fold (0.02 log units) above the measured number; measured number inside the range.
By their numbers in this assay, from the lowest: compounds 2, 4 and 1 (each within the scatter of the next); then compound 3.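

Adding a ring at this position, as 2-cyclohexylethyl on the amide-type nitrogen in a ring, gives a 2.6-fold lower number from compound 3 to compound 4 (0.42 log units; beyond the scatter) in this assay, so a substituent ending in a six-membered non-aromatic ring serves as well as the open-chain ones. Against those chains, the change gives no change at the digits printed from compound 2 to compound 4 (within the scatter) and a 1.2-fold lower number from compound 1 to compound 4 (0.09 log units; within the scatter), which leaves compound 1, compound 2 and compound 4 unseparated and only compound 3, with hydrogen, apart. Nothing in the data shown explains this. Going by these compounds, whether a chain ending in an amine, a carboxylic acid or a phenyl ring would keep this level remains open.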